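The source may hold more compounds than are shown below. What is called first, only, known or untested is meant among the compounds shown, and "the series" means these compounds.

Measured so far:
compound 1 `CNC(=O)c1ccc(-c2cnc3cnc(C(=O)N(C)c4ccc(C#N)cc4)cn23)cc1` — 5090 ng.h/mL
compound 2 `CN(C(=O)c1cn2c(-c3ccc(C(N)=O)cc3)cnc2cn1)c1ccc(F)cc1` — 4340 ng.h/mL

Both numbers come from an ADME assay on the whole organism (plasma) for pharmacokinetics, with Mus musculus as the target, at a dose of 20 mg/kg by the oral route; a lower number here means less compound in the circulation, a higher number more compound in the circulation at the dose given. In this assay compound 1 gives 5090 ng.h/mL, the higher of the two numbers, and compound 2 gives 4340 ng.h/mL, which sits within the scatter of the value for compound 1; the two results therefore cannot be set in any order. Among the compounds with values here, no step between measured compounds that differ in one place is available, so the move to compound 3 `CN(C(=O)c1cn2c(-c3ccc(-c4nnc(N)s4)cc3)cnc2cn1)c1ccc(C#N)cc1` has no measured precedent. Compound 3 differs from compound 1 in one place: 5-amino-1,3,4-thiadiazol-2-yl in place of methylcarbamoyl on an aromatic carbon. Without a comparable step, the expected size of the change in this assay is uncertain; a downward step of moderate size is expected, with the possibility that the result stays within the scatter of compound 1. The estimated step is a 2.0-fold lower number from compound 1 to compound 3 (0.31 log units; beyond the scatter). For compound 3 the expected exposure in this assay is 2500 ng.h/mL, with a range from 700 ng.h/mL to 7000 ng.h/mL.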

Compound 3, area under the concentration-time curve: 54.3 ng.h/mL
Estimate against measurement, compound 3: 46-fold (1.66 log units) above; the measured number lies below the stated range.
By their numbers in this assay, from the lowest: compound 3; then compounds 2 and 1 (each within the scatter of the next).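

In this assay, the position on an aromatic carbon of a six-membered aromatic ring of carbon only, para to a large group, proves highly sensitive: placing 5-amino-1,3,4-thiadiazol-2-yl there in place of methylcarbamoyl gives a 94-fold lower number from compound 1 to compound 3 (1.97 log units; beyond the scatter), with the rest of the structure unchanged. Within the data shown here, compound 1 and compound 2 differ in more than one place and offered no step, so this is the first single-place reading, and it shows that this one change can carry a large loss of circulating compound at the dose given. The hydrogen-bond donor count and the net charge are the same for the leaving and entering groups, but nothing available bears on why the number falls so far.

Open, going by these compounds, is whether the loss follows the five-membered aromatic ring itself or its amino group, which a 1,3,4-thiadiazol-2-yl group lacking that amine or a 1,3,4-oxadiazol-2-yl group at the same position would separate. Also open, on these data alone, is how a carboxylic acid or a longer amide chain at this position would compare with methylcarbamoyl on the same core.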